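The source may report more compounds than this note shows. Statements on the series, on what has been measured and on what is new or still open speak of the compounds shown alone.

The shared core, carried by compound 1 `O=C1C=C(NC2CCCCC2)C(=O)c2c1nc1n2[C@H]2OC[C@@H](O)[C@H]2OC1`, compound 2 `O=C1C(N2CCCC2)=CC(=O)c2c1nc1n2[C@H]2OC[C@@H](O)[C@H]2OC1` and compound 3 `Cc1ccc(NC2=CC(=O)c3nc4n(c3C2=O)[C@H]2OC[C@@H](O)[C@H]2OC4)cc1C`, is tested in a functional assay on MCF7 cells (Homo sapiens) for inhibition, read by sulforhodamine B assay; on this read-out lower numbers stand for stronger inhibition and higher numbers for weaker inhibition. Compound 2 reaches only a limit, > 16000 nM, so its potency is not pinned to a number, and it is one of two compounds left at a limit, as the limit of > 16000 nM in this assay, at which 1 of the 3 values shown sits, shows. Compound 1 also stops at a limit, > 8000 nM. Compound 3 gives 2080 nM. Compound 4 `O=C1C(Nc2cccc(F)c2)=CC(=O)c2c1nc1n2[C@H]2OC[C@@H](O)[C@H]2OC1` is not yet measured; it differs from compound 2 by (3-fluorophenyl)amino in place of pyrrolidin-1-yl on a double-bonded ring carbon. The one comparable move, an aromatic amine in place of a saturated amine, is an at least 3.8-fold lower number from compound 1 to compound 3 (0.58 log units; beyond the scatter), a step beyond the scatter toward stronger inhibition. A similar gain is therefore expected for compound 4, a step of an at least 3.2-fold lower number from compound 2 to compound 4 (0.50 log units; beyond the scatter), giving an estimated 5000 nM within 1500 nM to 16000 nM.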

Compound 4, half-maximal inhibitory concentration: > 4000 nM
Compound 4: only a limit was reported; the forecaster's own chance of this, stated with the estimate: 30%; the middle value is on the limit's open side.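

Compound 2 and compound 4 each stop at a limit, so the step between them cannot be read. Going by these compounds, whether (3-fluorophenyl)amino in place of pyrrolidin-1-yl strengthens inhibition at all, and by how much, stays open.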